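Chloro to Trifluoromethyl: One Change Tested Twice

The source may report more compounds than this note shows. Statements on the series, on what has been measured and on what is new or still open speak of the compounds shown alone.

Three compounds share one core. Compound 1 `Oc1cc(C(F)(F)F)ccc1-c1nc(-c2ccccc2O)n(-c2ccccc2Cl)n1` gives 90.6% in a functional assay on PC-12 cells (Rattus norvegicus) for cytotoxicity, read by MTT assay, with stated times of 2 h and 24 h, tested at 5 uM; on this read-out higher numbers stand for a stronger effect at the one concentration tested and lower numbers for a weaker effect. Compound 2 `Oc1cc(C(F)(F)F)ccc1-c1nc(-c2ccccc2O)n(-c2ccccc2C(F)(F)F)n1` gives 80% in this assay, and compound 3 `Oc1cc(C(F)(F)F)ccc1-c1nc(-c2ccccc2O)n(-c2cccc(Cl)c2)n1` gives 92.7%. The change trifluoromethyl in place of chloro on an aromatic carbon produced a number 10.6 percentage points lower from compound 1 to compound 2 (beyond the scatter). Compound 1 and compound 3 differ by 3-chlorophenyl in place of 2-chlorophenyl on an aromatic nitrogen, which gave a number 2.1 percentage points higher from compound 1 to compound 3 (within the scatter); the pair of compound 2 and compound 3 shows a number 12.7 percentage points higher from compound 2 to compound 3 (beyond the scatter). Compound 4 `Oc1cc(C(F)(F)F)ccc1-c1nc(-c2ccccc2O)n(-c2cccc(C(F)(F)F)c2)n1` is not yet measured and differs from compound 3 by trifluoromethyl in place of chloro on an aromatic carbon. This is the same kind of change as that from compound 1 to compound 2, but there the entering group sits ortho to a large group, here meta to a large group. Because a number 10.6 percentage points lower from compound 1 to compound 2 (beyond the scatter) went beyond the scatter, a modest fall is expected here too, a number 10.7 percentage points lower from compound 3 to compound 4 (beyond the scatter). Compound 4 is therefore estimated at 82%, between 72% and 92%.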

Compound 4, a percentage reported as activity, at one concentration (the size of the read-out at that concentration, not a potency): 92.2%
The estimate for compound 4 lay 10.2 percentage points below the measured number, outside the stated range (above it).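

In this assay, trifluoromethyl in place of chloro gave a number 0.5 percentage points lower from compound 3 to compound 4 (within the scatter), 3-(trifluoromethyl)phenyl in place of 2-(trifluoromethyl)phenyl gave a number 12.2 percentage points higher from compound 2 to compound 4 (beyond the scatter), and 3-(trifluoromethyl)phenyl in place of 2-chlorophenyl gave a number 1.6 percentage points higher from compound 1 to compound 4 (within the scatter). The two readings of the chloro to trifluoromethyl change cannot be told apart: the same change on two cores in this assay, a number 10.6 percentage points lower (beyond the scatter) from compound 1 to compound 2 and a number 0.5 percentage points lower (within the scatter) from compound 3 to compound 4, 10.1 percentage points apart, within the scatter of two such steps. Among these compounds, this does not show that the change behaves differently on the two cores, nor that it carries over with a fixed size, since only two pairs at a single concentration are available.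

The compounds shown leave open how an amine or a carboxylic acid would read at this place on the ring. They also leave open whether the same change would give a similar step on other cores.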